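The source may hold more compounds than are shown below. What is called first, only, known or untested is meant among the compounds shown, and "the series" means these compounds.

Compound 1 `Cc1cn(C2CC(N=[N+]=[N-])C(COC(=O)OCCCC(=O)OC(C)(C)C)O2)c(=O)[nH]c1=O` was examined in a functional assay on MT4 cells (Homo sapiens) for cytotoxicity; a lower number here means that less compound is tolerated, a higher number that more compound is tolerated. In this assay compound 1 reaches only the limit of > 50000 nM. Compound 2 `Cc1cn(C2CC(N=[N+]=[N-])C(COC(=O)OCCCN)O2)c(=O)[nH]c1=O` differs from compound 1 by amino in place of tert-butoxycarbonyl on a saturated chain carbon, three bonds along the chain from an oxygen next to a carbonyl group. In this assay compound 2 likewise shows only the limit of > 50000 nM. The step that the two limits leave unreadable from compound 1 to compound 2 cannot be read because of the limit of > 50000 nM in this assay, at which 3 of the 3 values shown sit. Compound 3 `Cc1cn(C2CC(N=[N+]=[N-])C(COC(=O)CCCC(=O)OC(C)(C)C)O2)c(=O)[nH]c1=O` gives only the limit of > 50000 nM in this assay. The step that the two limits leave unreadable from compound 2 to compound 3 is equally unreadable. The difference between the cores of compound 1 and compound 3 is not broken down here. Compound 4 `Cc1cn(C2CC(N=[N+]=[N-])C(COC(=O)CCCN)O2)c(=O)[nH]c1=O` remains unmeasured and differs from compound 3 by amino in place of tert-butoxycarbonyl on a saturated chain carbon, three bonds along the chain from a carbonyl carbon; this is the same kind of change as that from compound 1 to compound 2, the place there being three bonds along the chain from an oxygen next to a carbonyl group, here from a carbonyl carbon. Compound 4 is expected to give 60000 nM in this assay. That estimate corresponds to the step that the limit leaves unreadable from compound 3 to compound 4 and rests on (the limit of > 50000 nM in this assay, at which 3 of the 3 values shown sit).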

Compound 4, half-maximal cytotoxic concentration in the MT4 assay: > 50000 nM
Compound 4 ended at the assay's limit; the forecaster's own chance of this, stated with the estimate: 85%; the middle value lies beyond the limit too.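

In the MT4 assay compound 4 gives > 50000 nM, which is a limit of the assay. In the MT4 assay, the steps from compound 3 to compound 4 and from compound 2 to compound 4 cannot be read: the limit of > 50000 nM in the MT4 assay, at which 4 of the 4 values shown sit.

In a physicochemical assay for lipophilicity (a higher number here means a more lipophilic compound, a lower number a more polar compound), compound 3 gives 1.17. In the physicochemical assay compound 4 gives -0.9. In the physicochemical assay this is a number 2.07 log units lower from compound 3 to compound 4 (beyond the scatter).

The compounds shown leave open at what concentration, if any, compounds 1 to 4 become cytotoxic in the MT4 assay.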